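The source may report more compounds than this note shows. Statements on the series, on what has been measured and on what is new or still open speak of the compounds shown alone.

Measured so far in an assay on isolated protein for inhibition of DNA topoisomerase 1 (Homo sapiens), with a stated time of 15 min; on this read-out higher numbers stand for weaker inhibition and lower numbers for stronger inhibition:
- compound 1, `O=C(O)c1cn(Cc2ccc(-c3ccccc3)cc2)c2cc(NC[C@@H]3CCNC3)c(F)cc2c1=O`, gives 104000 nM
- compound 2, `O=C(O)c1cn(Cc2ccc(-n3cccn3)cc2)c2cc(NC[C@H]3CCNC3)c(F)cc2c1=O`, gives 187000 nM

Compound 2 stands at the higher of the two numbers, but its value and that of compound 1 lie within the usual scatter of each other, so the two values show no separation. Within the data shown here, compound 1 and compound 2 differ in two places at once, so no single step between them can be read.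

Compound 3, `O=C(O)c1cn(Cc2ccc(-n3cccn3)cc2)c2cc(NC[C@@H]3CCNC3)c(F)cc2c1=O`, is the next compound for this assay. Relative to compound 2 the change is: the two compounds have the same atoms and bonds and differ only in configuration as drawn: 1 of 1 stereo elements differ; a stereocentre at a saturated ring carbon is drawn S in compound 2 and R in compound 3. Among the measured compounds shown here, no measured pair shows the effect of inverting this stereocentre on its own. With both measured values in the same weak range, no step beyond the scatter is expected in either direction. The step of a 1.3-fold lower number from compound 2 to compound 3 (0.13 log units; within the scatter) is estimated to remain within the scatter. Compound 3 is expected at 140000 nM, with a range from 50000 nM to 400000 nM.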

Compound 3, half-maximal inhibitory concentration: 200000 nM
Estimate against measurement, compound 3: 1.4-fold (0.15 log units) below, and the stated range covers the measured number.
By their numbers in this assay, from the lowest: compounds 1, 2 and 3 (each within the scatter of the next).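

In this assay, inverting the stereocentre at the saturated ring carbon gives a 1.1-fold higher number from compound 2 to compound 3 (0.03 log units; within the scatter), so the S and R drawings show no separation with the 1H-pyrazol-1-yl group in place. This reading of the stereocentre as a single change rests on one point: the fact that compounds 2 and 3 differ only in the configuration as drawn

The series now also has a readable step for the aromatic group, where 1H-pyrazol-1-yl in place of phenyl gives a 1.9-fold higher number from compound 1 to compound 3 (0.28 log units; within the scatter), so these two groups show no separation either.

Going by these compounds, whether any single change can move this read-out at all remains open, as all three values lie within the scatter of one another. Also open, on these data alone, is how a cyclohexyl group in place of phenyl, or a methyl ester in place of the carboxylic acid, would read in this assay.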